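Notes on the six-ring substituent of the fused core

The compounds below may be only part of what the source reports. "The series", "measured", "known", "first", "only" and "open" are said of these compounds alone.

Measured so far:
compound 1 `COc1cc(OC)n2s/c(=N\C(=O)c3c(-c4ccc(Cl)cc4Cl)noc3C)nc2n1` — in a functional assay on the whole organism for inhibition, with Brassica napus as the target, with a stated time of 72 h, tested at 100 mg/L (on this read-out higher numbers stand for more inhibition of growth at the one concentration tested and lower numbers for less inhibition of growth), compound 1 gives 85.6%
compound 2 `COc1cc(Cl)nc2n/c(=N/C(=O)c3c(-c4ccc(Cl)cc4Cl)noc3C)sn12` — in this assay compound 2 gives 70.8%
compound 3 `COc1cc(SC)nc2n/c(=N/C(=O)c3c(-c4ccc(Cl)cc4Cl)noc3C)sn12` — not yet measured

Among the measured compounds shown here, compound 2 stands lowest of the two numbers so far; its only neighbour is compound 1, and the step of a number 14.8 percentage points lower from compound 1 to compound 2 (beyond the scatter) separates them, beyond the scatter. Compound 3 differs from compound 2 by methylsulfanyl in place of chloro on an aromatic carbon. For the measured compounds named here, no measured step swaps chloro for methylsulfanyl, so the single step that bears on this position is a number 14.8 percentage points lower from compound 1 to compound 2 (beyond the scatter), modest and beyond the scatter, where chloro entered for methoxy. With nothing directly comparable, the expectation for compound 3 in this assay is a step near the edge of the scatter, leaning upward toward compound 1, a number 6.2 percentage points higher from compound 2 to compound 3 (within the scatter). Compound 3 is therefore estimated at 77%, with a range from 62% to 90%.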

Compound 3, percent growth inhibition at one concentration: 75.8%
Compound 3: the middle estimate sits 1.2 percentage points above what was measured; the range from low to high includes it.
By their numbers in this assay, from the lowest: compounds 2, 3 and 1 (each within the scatter of the next, the first and the last beyond it).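

In this assay, chloro to methylsulfanyl gives a number 5 percentage points higher from compound 2 to compound 3 (within the scatter), and methoxy to methylsulfanyl gives a number 9.8 percentage points lower from compound 1 to compound 3 (within the scatter). Methylsulfanyl on this aromatic carbon therefore cannot be told apart from either earlier group, and the separation seen before remains only between the methoxy of compound 1 and the chloro of compound 2, so these three groups do not fall into a clear order. Nothing available on these compounds gives a reason for these numbers.

As far as these compounds go, how an amine or a longer chain such as butylsulfanyl would behave on this carbon remains open, and so does whether the position accepts groups well beyond these three. From the compounds shown here alone, with growth inhibition read at a single concentration, how these compounds compare at lower concentrations also remains open.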